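Hydroxypiperidine variation on the shared core

The source may hold more compounds than are shown below. What is called first, only, known or untested is meant among the compounds shown, and "the series" means these compounds.

Among the compounds with values here, compound 1 `COc1cc[nH]c1/C=C1\C(=O)Nc2ccc([N+](=O)[O-])c(N3CCC(O)CC3)c21` gives the only number so far in a functional assay on MDA-MB-435 cells (Homo sapiens) for antiproliferative activity, read by MTT assay, with a stated time of 5 days (on this read-out lower numbers stand for stronger inhibition and higher numbers for weaker inhibition), at 46 nM. Compound 2 `COc1cc[nH]c1/C=C1\C(=O)Nc2ccc(F)cc21` reaches only a limit of this assay, reported as > 30000 nM. Compound 3 `COc1cc[nH]c1/C=C1\C(=O)Nc2ccc([N+](=O)[O-])c(N3CCCC(CO)C3)c21` carries the change 3-(hydroxymethyl)piperidin-1-yl in place of 4-hydroxypiperidin-1-yl on an aromatic carbon relative to compound 1. Within the data shown here, no step between measured compounds covers a change of this kind, so the expected step of a 1.7-fold higher number from compound 1 to compound 3 (0.24 log units; within the scatter) is small, leaning toward weaker inhibition but not clearly beyond the usual scatter. Compound 3 is estimated at 80 nM in this assay, with a range from 25 nM to 300 nM.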

Compound 3, half-maximal inhibitory concentration: 441 nM
For compound 3 the middle estimate is 5.5-fold (0.74 log units) below the measured one; measured number outside the range, above it.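

In this assay, 3-(hydroxymethyl)piperidin-1-yl in place of 4-hydroxypiperidin-1-yl on the aromatic carbon ortho to a nitro group gives a 9.6-fold higher number from compound 1 to compound 3 (0.98 log units; beyond the scatter). Within the data shown here, this position therefore distinguishes between two hydroxylated six-membered rings attached through nitrogen, a difference the earlier compounds could not show. No measurement shown bears on the reason for this loss.

From the compounds shown here alone, whether it follows the moved hydroxyl, the extra carbon or both stays open, as 3-hydroxypiperidin-1-yl and 4-(hydroxymethyl)piperidin-1-yl would separate these. Going by these compounds, how unsubstituted piperidin-1-yl or morpholin-4-yl would compare here also stays open.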